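Swapping thiophen-3-yl for furan-3-yl in compound 1

A few compounds are considered here, and "the series" means these few. Any claim that something is new, unique, unknown or untested is made for them only; others in the source may bear on it.

In a functional assay on DU-145 cells (Homo sapiens) for cytotoxicity, read by CCK-8 assay (on this read-out higher numbers stand for weaker inhibition and lower numbers for stronger inhibition), compound 1 `Oc1ccc(-c2cc(-c3ccsc3)cc(-c3ccccc3O)n2)cc1` gives > 50000 nM, which is a limit of the assay and not a number. Compound 2 `Oc1ccc(-c2cc(-c3ccsc3)cc(-c3cccc(O)c3)n2)cc1` gives 2230 nM in this assay. Among the compounds with values here, the only measured step, an at least 22-fold lower number from compound 1 to compound 2 (1.35 log units; beyond the scatter), is large, but it puts 3-hydroxyphenyl in place of 2-hydroxyphenyl and leaves the thiophen-3-yl group untouched. Compound 3 `Oc1ccc(-c2cc(-c3ccoc3)cc(-c3ccccc3O)n2)cc1` keeps the 2-hydroxyphenyl group of compound 1 and instead puts furan-3-yl in place of thiophen-3-yl on an aromatic carbon. Within the data shown here, both groups are five-membered aromatic rings with 1 hetero atom, and no measured step covers this swap, so the large size of the hydroxyphenyl step does not carry over. The expected change is a number no higher from compound 1 to compound 3 (the limit leaves the size open), which means no step beyond the scatter is expected. Compound 3 is estimated at 50000 nM, with an expected range of 15000 nM to 100000 nM.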

Compound 3, half-maximal inhibitory concentration: 28000 nM
For compound 3 the middle estimate is 1.8-fold (0.25 log units) above the measured one; the range from low to high includes it.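

Furan-3-yl in place of thiophen-3-yl at this position, opposite the ring nitrogen, gives an at least 1.7-fold lower number from compound 1 to compound 3 (0.25 log units; that floor lies within the scatter). This is the first view of this position, and with the 2-hydroxyphenyl group kept, the swap of sulfur for oxygen in the five-membered ring brings the value of compound 3 inside the measurable range of this assay, yet the step shown is only a floor. The true size of the step stays unknown because compound 1 gives a limit of the assay and not a number: the limit of > 50000 nM in this assay, at which 1 of the 3 values shown sits.

Still open, going by these compounds, is whether the same swap would have a similar effect with the 3-hydroxyphenyl group of compound 2 in place. Also open, on these data alone, is how this position would respond to a group of another kind, such as an amine or a carboxylic acid.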